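This account rests on a few compounds, and the source may have more. Where it says the series, first, only, none or still open, it means among the compounds named here.

For the measured compounds named here, compound 2 `NC(=O)CNC[C@@H]1CCCc2cc(S(=O)(=O)c3cccc(F)c3)ccc21` gives 0.1 nM in an assay on isolated protein for displacement of a labelled ligand from 5-hydroxytryptamine receptor 6 (Homo sapiens) (a higher number here means a weaker inhibitor, a lower number a stronger inhibitor), the lowest of the two numbers measured so far. Going by the values given here, compound 1 `CN(C[C@@H]1CCCc2cc(S(=O)(=O)c3cccc(F)c3)ccc21)S(N)(=O)=O` gives 3.98 nM in this assay; the only measured step, a 40-fold lower number from compound 1 to compound 2 (1.60 log units; beyond the scatter), came from exchanging the group on the saturated chain carbon bound to a saturated ring carbon, so this is the position where the series has moved. Compound 3 `N=C(N)NC(=O)C[C@@H]1CCCc2cc(S(=O)(=O)c3cccc(F)c3)ccc21` carries a further exchange at the same place: a group of 6 heavy atoms (2 carbon, 3 nitrogen, 1 oxygen; no ring) in place of a group of 5 heavy atoms (2 carbon, 2 nitrogen, 1 oxygen; no ring), on a saturated chain carbon bound to a saturated ring carbon. Among the compounds with values here, no measured step involves the entering group, and nothing yet shows how far the low number of compound 2 carries when the (carbamoylmethyl)amino group is replaced again. Within the data shown here, the one step that bears on the position, a 40-fold lower number from compound 1 to compound 2 (1.60 log units; beyond the scatter), was large, so a change of similar size cannot be excluded; with compound 2 already the lowest number in the set, a move to a higher number is the more probable outcome. Compound 3 is therefore expected at 5 nM in this assay, within 0.5 nM to 50 nM. This estimate means a 50-fold higher number from compound 2 to compound 3 (1.70 log units; beyond the scatter).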

Compound 3, inhibition constant: 0.631 nM
Estimate against measurement, compound 3: 7.9-fold (0.90 log units) above; the range from low to high includes it.
By their numbers in this assay, from the lowest: compound 2; then compound 3; then compound 1.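

In this assay the saturated chain carbon bound to a saturated ring carbon now carries three different groups, and the new group of 6 heavy atoms (2 carbon, 3 nitrogen, 1 oxygen; no ring) lands in the middle of them: a 6.3-fold higher number from compound 2 to compound 3 (0.80 log units; beyond the scatter) on one side and a 6.3-fold lower number from compound 1 to compound 3 (0.80 log units; beyond the scatter) on the other, both beyond the scatter. The low number of compound 2 is therefore partly kept, but not fully, when the (carbamoylmethyl)amino group is replaced, which makes this position sensitive to the group it carries while still tolerating more than one group with a low number. Nothing available accounts for this order of the three groups.

Still open, on these data alone, is whether a plain primary amine, a carboxylic acid or a longer chain ending in a primary amide would stay near compound 2 at this position or fall back towards compound 1. Also open, as far as these compounds go, is whether the same order of groups holds when the rest of the shared core is changed, including the fluorine-bearing aromatic ring on the sulfonyl group.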